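The source may hold more compounds than are shown below. What is called first, only, known or untested is meant among the compounds shown, and "the series" means these compounds.

The measured compounds:
Compound 1, `O=C(Nc1cccc(-c2oc3cc(-c4ccc(F)cc4)ccc3c(=O)c2O)c1)c1ccc(F)cc1`: in a functional assay on GTL 16 cells for antiproliferative activity against GTL 16 cell line (Homo sapiens), read by CCK-8 assay, with a stated time of 72 h (on this read-out higher numbers stand for weaker inhibition and lower numbers for stronger inhibition), compound 1 gives 14600 nM.
Compound 2, `COc1ccccc1C(=O)Nc1cccc(-c2oc3cc(-c4ccc(F)cc4)ccc3c(=O)c2O)c1`: compound 2 gives 6370 nM.
Compound 3, `COc1cc(OC)cc(C(=O)Nc2cccc(-c3oc4cc(-c5ccc(F)cc5)ccc4c(=O)c3O)c2)c1`: compound 3 gives 19600 nM.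

Compound 3 carries the highest number of the three; it is within the scatter of compound 1 but separated from compound 2, as shown by a 3.1-fold higher number from compound 2 to compound 3 (0.49 log units; beyond the scatter). Compound 4, `O=C(Nc1cccc(-c2oc3cc(-c4ccc(F)cc4)ccc3c(=O)c2O)c1)c1cc(F)cc(F)c1`, differs from compound 3 by 3,5-difluorophenyl in place of 3,5-dimethoxyphenyl on a carbonyl carbon. Within the data shown here, the step that bears on this is the one between compound 1 and compound 3, a 1.3-fold higher number from compound 1 to compound 3 (0.13 log units; within the scatter), which stayed within the scatter when a fluorine-bearing ring replaced the dimethoxy ring. A fluorine-bearing ring again enters here, so no step beyond the scatter is expected in this assay. Compound 4 is therefore estimated at 15000 nM, with a range from 6000 nM to 38000 nM. The expected step is a 1.3-fold lower number from compound 3 to compound 4 (0.12 log units; within the scatter).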

Compound 4, half-maximal inhibitory concentration: 7410 nM
Compound 4: middle estimate off by 2.0-fold (0.31 log units), on the high side; the range from low to high includes it.
By their numbers in this assay, from the lowest: compounds 2, 4, 1 and 3 (each within the scatter of the next, the first and the last beyond it).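

In this assay the 3,5-difluorophenyl ring on the carbonyl carbon gives a 2.6-fold lower number from compound 3 to compound 4 (0.42 log units; beyond the scatter), so a fluorine-bearing ring is now separated from the 3,5-dimethoxyphenyl ring, which the 4-fluorophenyl ring of compound 1 was not. Compound 4 still stays level with the two other compounds, at a 1.2-fold higher number from compound 2 to compound 4 (0.07 log units; within the scatter) and a 2.0-fold lower number from compound 1 to compound 4 (0.29 log units; within the scatter), although those two are separated from each other. Nothing measured here accounts for the difference between the two rings. Still open, going by these compounds, is how this position responds to a ring carrying an amine or a carboxylic acid, or to a longer chain in place of the ring.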